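Replacing bromomethyl with acetoxymethyl in compound 3

The source may report more compounds than this note shows. Statements on the series, on what has been measured and on what is new or still open speak of the compounds shown alone.

In a functional assay on SK-BR-3 cells (Homo sapiens) for cytotoxicity, read by MTT assay, with a stated time of 72 h (a higher number here means that more compound is needed for the effect, a lower number that less compound is needed), compound 1 `CCc1cccc2c(OC)c(-c3occ(C)c3C(=O)OC)ccc12` gives 1.2 ug/mL and compound 2 `CCc1cccc2c(OC)c(-c3occ(C)c3CO)ccc12` gives 0.73 ug/mL. Compound 3 `CCc1cccc2c(OC)c(-c3occ(C)c3CBr)ccc12` gives no number in this assay, only a limit, > 10 ug/mL. Among the measured compounds shown here, of the three measured compounds, compound 3 is thus the one whose value is known only as a limit (the limit of > 10 ug/mL in this assay, at which 1 of the 3 values shown sits). The change to compound 4 `CCc1cccc2c(OC)c(-c3occ(C)c3COC(C)=O)ccc12` is acetoxy in place of bromo on a saturated chain carbon bound to an aromatic carbon. For the measured compounds named here, the steps that bear on it are an at least 13-fold higher number from compound 2 to compound 3 (1.13 log units; beyond the scatter) and an at least 8.3-fold higher number from compound 1 to compound 3 (0.92 log units; beyond the scatter), while a 1.6-fold lower number from compound 1 to compound 2 (0.22 log units; within the scatter) shows the ester and hydroxymethyl analogues close together. Replacing the bromo is therefore expected to move the number back toward those of compound 1 and compound 2. The expected step is an at least 6.6-fold lower number from compound 3 to compound 4 (0.82 log units; beyond the scatter). Compound 4 is expected at 1.5 ug/mL, with a range from 0.5 ug/mL to 5 ug/mL.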

Compound 4, concentration for half-maximal effect: > 10 ug/mL
Compound 4 was reported as a limit; the forecaster's own chance of this, stated with the estimate: 15%; at least 6.6-fold (0.82 log units) between middle value and limit.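

Acetoxymethyl at this place does not restore a measurable number in this assay, unlike the methoxycarbonyl and hydroxymethyl groups: an at least 13-fold higher number from compound 2 to compound 4 (1.13 log units; beyond the scatter), and an at least 8.3-fold higher number from compound 1 to compound 4 (0.92 log units; beyond the scatter). Among the compounds shown here, the bromo is therefore not the only change on this saturated chain carbon that goes with the loss, as a group without bromine behaves the same way within this assay's range. The step from compound 3 to compound 4 cannot be read, since both are reported only as a limit: the limit of > 10 ug/mL in this assay, at which 2 of the 4 values shown sit.

As far as these compounds go, how the two compounds rank beyond that limit stays open. Also open, from the compounds shown here alone, is whether an aminomethyl group or a carboxylic acid at this place would give a measured number.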